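Carbamate to trifluoroacetyl on the piperidine nitrogen

This account rests on a few compounds, and the source may have more. Where it says the series, first, only, none or still open, it means among the compounds named here.

Within the data shown here, compound 2 `Cc1nc(S(C)(=O)=O)ccc1Oc1ncnc(OC2CCN(C(=O)O[C@@H](C)C(F)(F)F)CC2)c1F` gives 80% in a functional assay on isolated protein for inhibition of Glucose-dependent insulinotropic receptor (Rattus norvegicus), read by HTRF and cAMP accumulation (a lower number here means a smaller maximal response, a higher number a larger maximal response), the lower of the two numbers measured so far; compound 1 `Cc1nc(S(C)(=O)=O)ccc1Oc1ncnc(OC2CCN(C(=O)OC(C)(C)CF)CC2)c1F` gives 95%. Among the measured compounds shown here, the one measured step, a number 15 percentage points lower from compound 1 to compound 2 (beyond the scatter), concerns only the group on the oxygen of the carbamate. Compound 3 `Cc1nc(S(C)(=O)=O)ccc1Oc1ncnc(OC2CCN(C(=O)C(F)(F)F)CC2)c1F` differs from compound 2 by trifluoromethyl in place of 1-(trifluoromethyl)ethoxy on a carbonyl carbon; the alkoxy part is removed altogether, so the measured step bears on it only loosely. A modest further fall, or no step beyond the scatter, is expected for compound 3: a number 8 percentage points lower from compound 2 to compound 3 (within the scatter). The estimate for compound 3 is 72%, with a range from 55% to 90%.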

Compound 3, largest response reached (reported as efficacy), in percent of the reference or control that the assay uses: 76%
The estimate for compound 3 lay 4 percentage points below the measured number; low and high end bracket the measured number.
By their numbers in this assay, from the lowest: compounds 3 and 2 (each within the scatter of the next); then compound 1.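

In this assay, loss of the alkoxy part leaves no step beyond the scatter, with a number 4 percentage points lower from compound 2 to compound 3 (within the scatter), so at this carbonyl carbon trifluoromethyl and 1-(trifluoromethyl)ethoxy cannot be told apart. The wider comparison gives a number 19 percentage points lower from compound 1 to compound 3 (beyond the scatter), so compound 1 remains apart from both other compounds. No available evidence accounts for these differences.

Going by these compounds, it remains open whether an amine on the carbonyl carbon, giving a urea, or a longer alkyl chain in place of trifluoromethyl would keep this response. On these data alone, whether fluorine is needed in the group also remains open, as a plain methyl would test.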